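The source may report more compounds than this note shows. Statements on the series, on what has been measured and on what is new or still open speak of the compounds shown alone.

Measured so far in this study:
compound 1 `COc1cc(-c2cc(-c3cccc([N+](=O)[O-])c3)nc(-c3ccccc3)n2)cc(OC)c1OC` — > 25000 nM
compound 2 `COc1cc(-c2cc(-c3cccc(O)c3)nc(-c3ccccc3)n2)cc(OC)c1OC` — 20400 nM

Both numbers come from a functional assay on HCT-116 cells (Homo sapiens) for inhibition, read by MTT assay, with a stated time of 48 h; on this read-out higher numbers stand for weaker inhibition and lower numbers for stronger inhibition. Compound 1 reaches only the limit of this assay, so no number is known for it; that limit is recorded as the limit of > 25000 nM in this assay, at which 1 of the 2 values shown sits. Compound 2 gives 20400 nM in this assay. For the measured compounds named here, the one measured step, an at least 1.2-fold lower number from compound 1 to compound 2 (0.08 log units; that floor lies within the scatter), starts from a limit and lies within the scatter, so it shows no more than that both compounds sit at the weak end of the range.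

Compound 3 `COc1cc(-c2cc(-c3cccs3)nc(-c3ccccc3)n2)cc(OC)c1OC` has not yet been measured in this assay. It differs from compound 1 in one place: thiophen-2-yl in place of 3-nitrophenyl on an aromatic carbon. Going by the values given here, no measured step bears directly on this change; the only measured step, hydroxy in place of nitro, stays within the scatter and gives no guide to the direction of a swap of the whole ring. Compound 1 stands at the limit, so the expected number for compound 3 can only be lower than that limit or again at it. With nothing to point either way, compound 3 is expected to give 18000 nM, between 5000 nM and 25000 nM. The expected step of an at least 1.3-fold lower number from compound 1 to compound 3 (0.14 log units; that floor lies within the scatter) is therefore slight, with a real chance that compound 3 too is reported only as a limit.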

Compound 3, half-maximal inhibitory concentration: 17000 nM
Compound 3: the middle estimate sits 1.1-fold (0.02 log units) above what was measured; the range from low to high includes it.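

In this assay, for the compounds shown here, exchanging the whole 3-nitrophenyl ring for thiophen-2-yl gives an at least 1.4-fold lower number from compound 1 to compound 3 (0.16 log units; that floor lies within the scatter), so this change tests the entire ring at this position, where the earlier step altered only one group on it. Compound 1 is recorded only as a limit, so this step can be read only as a floor: the limit of > 25000 nM in this assay, at which 1 of the 3 values shown sits.

The comparison with the hydroxy-bearing ring gives a 1.2-fold lower number from compound 2 to compound 3 (0.08 log units; within the scatter), which means that thiophen-2-yl, a five-membered ring with sulfur, and 3-hydroxyphenyl, a six-membered carbon ring, cannot be told apart at this position in this assay, and both leave the series at the weak end of the range.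

Going by these compounds, what stays open is whether any group at this position can move the number beyond the scatter, for instance a phenyl ring carrying an amine or a carboxylic acid, or a pyridine ring in place of thiophen-2-yl. On these data alone, it also stays open whether replacing the phenyl group elsewhere on the shared core would change the number more than any swap at this position has so far.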